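Bromo for fluoro on the N-aryl ring: compound 3 to 4

The source may hold more compounds than are shown below. What is called first, only, known or untested is meant among the compounds shown, and "the series" means these compounds.

Measured so far:
compound 1 `O=C(Nc1ccc(Oc2ccnc3[nH]ccc23)c(F)c1)c1cc2cccnc2n(-c2ccc(Br)cc2)c1=O` — 210 nM
compound 2 `Cn1ccc2c(Oc3ccc(NC(=O)c4cc5cccnc5n(-c5ccc(Br)cc5)c4=O)cc3)ccnc21` — 680 nM
compound 3 `Cn1ccc2c(Oc3ccc(NC(=O)c4cc5cccnc5n(-c5ccc(F)cc5)c4=O)cc3F)ccnc21` — 280 nM

All three were run in a functional assay on A549 cells (Homo sapiens) for antiproliferative activity, read by MTT assay, with a stated time of 72 h; on this read-out higher numbers stand for weaker inhibition and lower numbers for stronger inhibition. Compound 3 stands between the other two numbers: against compound 1 the gap lies within the scatter, so the two are not told apart; against compound 2 the gap lies beyond the scatter, compound 2 giving the higher number, that is, the weaker inhibition. Going by the values given here, no pair among the measured compounds differs in one place only, so no single-change step is in hand.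

Compound 4 `Cn1ccc2c(Oc3ccc(NC(=O)c4cc5cccnc5n(-c5ccc(Br)cc5)c4=O)cc3F)ccnc21` is compound 3 with one change: bromo in place of fluoro on an aromatic carbon. Among the compounds with values here, nothing among the measured compounds isolates this exchange. The two bromo compounds bracket the fluoro compound 3 in this assay, one within and one beyond the scatter of it, so no direction is indicated. The step from compound 3 to compound 4 is expected to be small, a 1.1-fold higher number from compound 3 to compound 4 (0.03 log units; within the scatter), not beyond the scatter. Compound 4 is estimated at 300 nM in this assay, with a range from 120 nM to 800 nM.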

Compound 4, half-maximal inhibitory concentration: 390 nM
Compound 4: the middle estimate sits 1.3-fold (0.11 log units) below what was measured; the measured number falls inside the stated range.
By their numbers in this assay, from the lowest: compounds 1, 3, 4 and 2 (each within the scatter of the next, the first and the last beyond it).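

In this assay, the exchange of 4-fluorophenyl for 4-bromophenyl can now be read on its own: a 1.4-fold higher number from compound 3 to compound 4 (0.14 log units; within the scatter), so fluoro and bromo are not told apart at this place, para to a large group. Going by these compounds alone, compound 4 also gives the first single-change readings at two other places, with fluoro in place of hydrogen on an aromatic carbon giving a 1.7-fold lower number from compound 2 to compound 4 (0.24 log units; within the scatter) and methyl in place of hydrogen on an aromatic nitrogen giving a 1.9-fold higher number from compound 1 to compound 4 (0.27 log units; within the scatter), so neither change is told apart from the scatter in this assay. Nothing at hand bears on the reason for any of these three readings.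

The compounds shown cover only two halogens on this phenyl ring, so a methoxy group, an amine or a carboxylic acid at the same place remains open, as does the unsubstituted phenyl ring. Whether bromo and fluoro also remain untold apart with the other combinations of the ring fluoro and the nitrogen methyl is open too, since the exchange has been read in a single pair.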